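This account rests on a few compounds, and the source may have more. Where it says the series, first, only, none or still open, it means among the compounds named here.

Three compounds have been measured so far in an ADME assay on microsomes from liver (Mus musculus) for metabolic stability, read by LC-MS, with a stated time of 10 min, tested at 0.5 uM; a higher number here means that more of the compound is left, a lower number that less of the compound is left:

- compound 1 `CCN1CCN(CCCN(C[C@H]2Cc3ccccc3CN2)[C@H]2CCCc3cccnc32)CC1` gives 19%
- compound 2 `c1cnc2c(c1)CN[C@H](CN(CCCN1CCNCC1)[C@H]1CCCc3cccnc31)C2` gives 63%
- compound 3 `c1cnc(CN(CCCN2CCNCC2)[C@H]2CCCc3cccnc32)nc1` gives 78%

Compound 1 stands lowest of the three, and both other values lie beyond the scatter from it. Compound 4 `c1ccc2c(c1)CN[C@@H](CN(CCCCN1CCNCC1)[C@H]1CCCc3cccnc31)C2` has not yet been measured. It departs from compound 1 by (piperazin-1-yl)methyl in place of 4-ethylpiperazin-1-yl on a saturated chain carbon, three bonds along the chain from an amine nitrogen and the same difference can be read as 3-(4-ethylpiperazin-1-yl)propyl giving way to 4-(piperazin-1-yl)butyl.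

Among the compounds with values here, no measured step isolates this change. The only one, a number 15 percentage points higher from compound 2 to compound 3 (beyond the scatter) and modest in size, lies at another place, on a saturated chain carbon bound to an amine nitrogen, so it offers only a rough scale. Compound 2 at 63% and compound 3 at 78% also carry a piperazine without the ethyl group, and both stand higher than compound 1, but they differ from it elsewhere as well. Within the data shown here, a modest upward move is therefore expected, of about the size of the one measured step, with much uncertainty. The estimated change is a number 16 percentage points higher from compound 1 to compound 4 (beyond the scatter) in this expectation. Compound 4 is expected at 35% within an estimated range from 15% to 60% for repeated measurements.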

Compound 4, percent of the compound remaining: 96%
Beside the measured number, compound 4's estimate is 61 percentage points below it, and the stated range ends below it.
By their numbers in this assay, from the lowest: compound 1; then compound 2; then compound 3; then compound 4.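

In this assay, replacing 3-(4-ethylpiperazin-1-yl)propyl with 4-(piperazin-1-yl)butyl on the core of compound 1 gives a number 77 percentage points higher from compound 1 to compound 4 (beyond the scatter), so the end of this chain has a large bearing on how much compound remains. Within the data shown here, until now, the only readable step lay at another place, a number 15 percentage points higher from compound 2 to compound 3 (beyond the scatter), and none of the earlier pairs isolated this part of the molecule. No measurement offered here explains why the number rises so far, and the cause of the rise stays unknown.

The single step joins two differences, the loss of the ethyl group and the longer chain, and the compounds shown cannot assign the rise to either one or to both together. A 3-(piperazin-1-yl)propyl or a 4-(4-ethylpiperazin-1-yl)butyl chain on the core of compound 1 would separate them, while a 4-(4-methylpiperazin-1-yl)butyl chain would show whether a smaller group on that piperazine nitrogen behaves like the ethyl group or like the free piperazine.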